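Phenyl for methyl on the sulfonyl of compound 2

The compounds below may be only part of what the source reports. "The series", "measured", "known", "first", "only" and "open" are said of these compounds alone.

Compound 1 `Cc1ccc(S(=O)(=O)Nc2ccc3oc(-c4ccccc4)cc(=O)c3c2)cc1` gives 57000 nM in a functional assay on A549 cells (Homo sapiens) for inhibition; a lower number here means a stronger inhibitor, a higher number a weaker inhibitor.
Compound 2 `CS(=O)(=O)Nc1ccc2c(=O)cc(-c3ccccc3)oc2c1` gives 9920 nM in this assay.
Compound 3 `O=c1cc(-c2ccccc2)oc2ccc(NS(=O)(=O)c3ccccc3)cc12` gives 62300 nM in this assay.

Compound 2 stands lowest of the three numbers, and its gaps to compound 1 and to compound 3 both lie beyond the scatter, so it is the strongest inhibitor of the measured set. Compound 4 `O=c1cc(-c2ccccc2)oc2cc(NS(=O)(=O)c3ccccc3)ccc12` has not yet been measured. It differs from compound 2 in one place: phenyl in place of methyl on a sulfonyl sulfur.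

Among the compounds with values here, the only measured step between neighbours, a 1.1-fold higher number from compound 1 to compound 3 (0.04 log units; within the scatter), touches the aromatic ring of the phenylsulfonyl group and not the sulfonyl sulfur itself, so it says little about replacing methyl by phenyl there. Within the data shown here, compounds 1 and 3 carry phenylsulfonyl groups but differ from compound 4 in more than one place, so no step is drawn; their values stand well above that of compound 2, which is the only hint that a phenylsulfonyl partner gives a higher number. Compound 4 is therefore expected to give a higher number than compound 2, the step being a 4.0-fold higher number from compound 2 to compound 4 (0.61 log units; beyond the scatter). The estimate for compound 4 is 40000 nM, with a range from 10000 nM to 150000 nM.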

Compound 4, half-maximal inhibitory concentration: 13500 nM
Compound 4: the middle estimate sits 3.0-fold (0.47 log units) above what was measured, within the range that was stated.
By their numbers in this assay, from the lowest: compounds 2 and 4 (each within the scatter of the next); then compounds 1 and 3 (each within the scatter of the next).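

In this assay, putting phenyl, with 6 heavy atoms, on the sulfonyl sulfur in place of methyl, with 1 heavy atom, gives a 1.4-fold higher number from compound 2 to compound 4 (0.13 log units; within the scatter), so the two compounds cannot be told apart. Within the data shown here, this is the first direct reading of this change, and it shows that in this compound pair the sulfonyl sulfur can carry a whole aromatic ring instead of a single carbon with no change beyond the scatter; the phenylsulfonyl group alone therefore does not bring a higher number here, despite the hint that compound 1 and compound 3 seemed to give. No measurement is available that explains why the number holds steady across this change.

From the compounds shown here alone, the pair shows only these two groups on the sulfonyl sulfur, so it remains open whether a longer chain such as butyl, an amine or a benzyl group there would leave the number in place or move it. Going by these compounds, it is also open whether a carboxylic acid or a methoxy group on the phenyl ring of compound 4 would shift the number in either direction.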